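The source may hold more compounds than are shown below. What is called first, only, known or untested is meant among the compounds shown, and "the series" means these compounds.

Within the data shown here, compound 2 `CCCCCOc1nc(N)nc2c1ncn2/C=C1/CC1(CO)CO` is one of two compounds measured in an ADME assay on CCRF-HSB-2 cells (Homo sapiens) for cytotoxicity, with a stated time of 7 days; a higher number here means that more compound is tolerated, a lower number that less compound is tolerated. Compound 1 `Nc1nc(NC2CC2)c2ncn(/C=C3/CC3(CO)CO)c2n1` carries cyclopropylamino on an aromatic carbon where compound 2 carries pentyloxy. In this assay compound 1 gives only a limit of the assay, > 20000 nM. In this assay compound 2 likewise gives only a limit, > 20000 nM. The step that the two limits leave unreadable from compound 1 to compound 2 therefore has no readable size, and compound 2 stands at the limit of > 20000 nM in this assay, at which 2 of the 2 values shown sit. Compound 3 `CCCCSc1nc(N)nc2c1ncn2/C=C1/CC1(CO)CO` differs from compound 2 by butylsulfanyl in place of pentyloxy on an aromatic carbon. Among the measured compounds shown here, the one measured step is unreadable, so no measured step supplies a size for this change; the two values show only that both compounds sit at the limit. The expected step that the limit leaves unreadable from compound 2 to compound 3 is none beyond the scatter. Compound 3 is expected to sit at the same limit, estimated in this assay at 25000 nM, within 8000 nM to 80000 nM.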

Compound 3, half-maximal cytotoxic concentration: 89000 nM
The estimate for compound 3 lay 3.6-fold (0.55 log units) below the measured number; measured number outside the range, above it.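

In this assay, the steps from compound 1 and compound 2 to compound 3 cannot be read, as compound 1 and compound 2 give only a limit: the limit of > 20000 nM in this assay, at which 2 of the 3 values shown sit. The compounds shown leave open whether butylsulfanyl, pentyloxy and cyclopropylamino differ at all in this read-out.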